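The compounds below may be only part of what the source reports. "The series", "measured", "known", "first", "only" and "open" are said of these compounds alone.

In a functional assay on B16-F1 cells (Mus musculus) for antiproliferative activity, read by MTT assay, with a stated time of 72 h (on this read-out higher numbers stand for weaker inhibition and lower numbers for stronger inhibition), the measured compounds stand as follows:

Compound 1 `C/C=C1/[C@H](O[C@@H]2O[C@H](COC(C)=O)[C@@H](OC(C)=O)[C@H](OC(C)=O)[C@H]2OC(C)=O)OC=C(C(=O)OC)[C@H]1CC(=O)OCCCCCCCCCCCCCCC` gives 34100 nM.
Compound 2 `C/C=C1/[C@H](O[C@@H]2O[C@H](CO)[C@@H](O)[C@H](O)[C@H]2O)OC=C(C(=O)OC)[C@H]1CC(=O)OCCC1CCCCC1` gives 5040 nM.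
Compound 3 `C/C=C1/[C@H](O[C@@H]2O[C@H](CO)[C@@H](O)[C@H](O)[C@H]2O)OC=C(C(=O)O)[C@H]1CC(=O)O` reaches only a limit of the assay, > 50000 nM.

Compound 2 therefore holds the lowest of the two numbers; compound 1 sits higher by a gap beyond the scatter. The limit of compound 3 is noted as the limit of > 50000 nM in this assay, at which 1 of the 3 values shown sits.

Compound 4 `C/C=C1/[C@H](O[C@@H]2O[C@H](CO)[C@@H](O)[C@H](O)[C@H]2O)OC=C(C(=O)OC)[C@H]1CC(=O)OCCc1ccccc1` differs from compound 2 by phenyl in place of cyclohexyl on a saturated chain carbon, two bonds along the chain from an oxygen next to a carbonyl group. Going by the values given here, no measured pair isolates this change, so its size cannot be read from the data. The step of a 1.2-fold higher number from compound 2 to compound 4 (0.08 log units; within the scatter) is expected to stay within the scatter, in either direction. Compound 4 is accordingly estimated at 6000 nM, with a range from 2000 nM to 18000 nM.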

Compound 4, half-maximal inhibitory concentration: 41000 nM
Estimate against measurement, compound 4: 6.8-fold (0.83 log units) below; the measured number lies above the stated range.
By their numbers in this assay, from the lowest: compound 2; then compounds 1 and 4 (each within the scatter of the next). At a limit, above all of these: compound 3.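

In this assay, going by these compounds alone, cyclohexyl and phenyl prove not to be interchangeable at this place: phenyl in place of cyclohexyl on a saturated chain carbon, two bonds along the chain from an oxygen next to a carbonyl group, gives an 8.1-fold higher number from compound 2 to compound 4 (0.91 log units; beyond the scatter) and is the first step that can be read here. Compound 3 alone remains at a limit of the assay: the limit of > 50000 nM in this assay, at which 1 of the 4 values shown sits.

The compounds shown give no cause for this step. They leave open whether a longer chain carrying the cyclohexyl, or a pyridine in place of the phenyl, would keep the lower number of compound 2.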